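A second fluoro on compound 1, at the assay limit

The source may hold more compounds than are shown below. What is called first, only, known or untested is meant among the compounds shown, and "the series" means these compounds.

Compound 1 `Cc1nnsc1CO/N=C/c1c(C)nn(C)c1Oc1cccc(F)c1` stands at > 50000 nM in a functional assay on Huh-7 cells (Homo sapiens) for inhibition, read by MTT assay, with a stated time of 48 h (a lower number here means a stronger inhibitor, a higher number a weaker inhibitor), and this is a limit, not a number. Compound 2 `Cc1nnsc1CO/N=C/c1c(C)nn(C)c1Oc1ccc(F)cc1` gives > 50000 nM as a limit too. Compound 3 `Cc1ccc(Oc2c(/C=N/OCc3snnc3C)c(C)nn2C)cc1` gives > 50000 nM as a limit too. Among the measured compounds shown here, the series so far holds no number: the limit of > 50000 nM in this assay, at which 3 of the 3 values shown sit, applies throughout.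

Compound 4 `Cc1nnsc1CO/N=C/c1c(C)nn(C)c1Oc1cc(F)cc(F)c1` follows from compound 1 by fluoro in place of hydrogen on an aromatic carbon so that 3-fluorophenyl becomes 3,5-difluorophenyl. The measured steps that bear on this are a step that the two limits leave unreadable from compound 1 to compound 2 and a step that the two limits leave unreadable from compound 1 to compound 3 and a step that the two limits leave unreadable from compound 2 to compound 3 and none has a readable size. No shift is expected in this assay and the estimated step that the limit leaves unreadable from compound 1 to compound 4 stays within the scatter. For compound 4 the estimate is 60000 nM with an expected range from 30000 nM to 120000 nM and a report as a limit is the likeliest outcome.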

Compound 4, half-maximal inhibitory concentration: > 50000 nM
Compound 4: only a limit was reported; the forecaster's own chance of this, stated with the estimate: 85%; the middle value does not contradict the limit.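

No step can be read between compound 4 and compound 1, compound 2 or compound 3, because all four sit at the same limit: the limit of > 50000 nM in this assay, at which 4 of the 4 values shown sit.

The compounds shown leave open whether any group on the phenyl ring gives a measurable value.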